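The source may report more compounds than this note shows. Statements on the series, on what has been measured and on what is new or still open speak of the compounds shown alone.

Compound 3, drawn as `NC(=O)c1cccc2c1CCOC2=O`, is the starting point of this comparison. In an ADME assay on HepG2 2.2.15 cells (Homo sapiens) for cytotoxicity, read by MTT assay, with a stated time of 72 h (on this read-out lower numbers stand for higher toxicity in this test and higher numbers for lower toxicity in this test), compound 3 gives > 3290000 nM, which is a limit of the assay rather than a measured number. In other words, compound 3 stands at the limit of > 3290000 nM in this assay, at which 1 of the 3 values shown sits. Two further compounds built on the same core have real numbers: compound 1, drawn as `O=C(O)c1ccccc1C(=O)OCc1cccc2c1CCOC2=O`, gives 130000 nM, and compound 2, drawn as `O=C(OCc1cccc2c1CCOC2=O)c1cc2ccccc2o1`, gives 830000 nM. Among the compounds with values here, neither of these differs from compound 3 in a single place, so their values show only that all three compounds sit at high concentrations in this assay.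

Compound 4, drawn as `O=C1OCCc2c1cccc2C1OCCO1`, is the one still to be measured. It differs from compound 3 by 1,3-dioxolan-2-yl in place of carbamoyl on an aromatic carbon. Within the data shown here, no measured step of this kind exists, so the expectation rests on the shared core alone. The step from compound 3 to compound 4 is expected to be an at least 1.6-fold lower number from compound 3 to compound 4 (0.21 log units; that floor lies within the scatter), roughly none beyond the usual scatter, with a modest chance that compound 4 falls somewhat lower because compound 3 itself only reached > 3290000 nM. For compound 4 the estimated value is 2000000 nM, within a range from 500000 nM to 5000000 nM.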

Compound 4, half-maximal cytotoxic concentration: > 2580000 nM
Compound 4 ended at the assay's limit; the forecaster's own chance of this, stated with the estimate: 45%; at least 1.2-fold (0.11 log units) between middle value and limit.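

Compound 3 and compound 4 both ended at a limit of the test rather than at a measured number, so the step between them cannot be read. The compounds shown leave open what real value lies behind each limit, and whether 1,3-dioxolan-2-yl in place of carbamoyl changes cytotoxicity at all.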